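Swapping a Side Chain for Phenyl: Expected Clearance

A few compounds are considered here, and "the series" means these few. Any claim that something is new, unique, unknown or untested is made for them only; others in the source may bear on it.

Measured so far:
- compound 1, `COC(C)(C)[C@@H](O)C(=O)N1N=CC[C@H]1C(=O)NCc1cc(Cl)ccc1-n1cnnn1`: < 12 mL.min-1.g-1
- compound 2, `O=C(NCc1cc(Cl)ccc1-n1cnnn1)[C@@H]1C[C@@H]2C[C@@H]2N1C(=O)[C@H](O)c1ccccc1`: < 16 mL.min-1.g-1

Both values come from an ADME assay on liver for metabolic stability, with Liver microsome (Homo sapiens) as the target, read by LC-MS, using microsomes; on this read-out higher numbers stand for fast clearance and lower numbers for slow clearance. The value of compound 1 is a limit of the assay, not a number, and compound 2 is also at a limit of the assay. Compound 3, `O=C(NCc1cc(Cl)ccc1-n1cnnn1)[C@@H]1CC=NN1C(=O)[C@H](O)c1ccccc1`, is not yet measured. It differs from compound 1 by phenyl in place of 1-methoxy-1-methylethyl on a saturated chain carbon bound to a carbonyl carbon and an oxygen on a saturated carbon. Since compound 1 sits at the limit of < 12 mL.min-1.g-1 in this assay, at which 1 of the 2 values shown sits, little room remains for a step downward. Compound 3 is expected to stay at slow clearance, with a step that the limit leaves unreadable from compound 1 to compound 3 being no step beyond the scatter. The estimate for compound 3 is 10 mL.min-1.g-1, between 4 mL.min-1.g-1 and 25 mL.min-1.g-1.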

Compound 3, intrinsic clearance in microsomes: < 12 mL.min-1.g-1
Compound 3 was reported as a limit; the forecaster's own chance of this, stated with the estimate: 60%; the middle value is on the limit's open side.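

Among the compounds shown here, compound 1 and compound 3 are each reported only as a limit of the assay, and no step between them can be read. The compounds shown leave open whether phenyl or 1-methoxy-1-methylethyl gives slower clearance.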